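Changing the Distal Aryl Group on a Shared Core

The compounds below may be only part of what the source reports. "The series", "measured", "known", "first", "only" and "open" are said of these compounds alone.

Compound 1, `COc1ccccc1Oc1ccc2c(NCCCNCc3ccco3)ccnc2c1`, gives 9.28 in a physicochemical assay for acid dissociation.
Compound 2, `COc1cccc(CNCCCNc2ccnc3cc(Oc4ccc(Cl)cc4)ccc23)c1O`, gives 9.28 in this assay.
Compound 3, `CC(C)(C)c1ccc(Oc2ccc3c(NCCCNCc4ccco4)ccnc3c2)cc1`, gives 9.28 in this assay.

Compound 2 stands level with compound 1 and compound 3 at the digits shown; its nearest neighbour is compound 1, and its furthest is compound 3, with neither gap going beyond the scatter. The unmeasured compound 4, `COc1cccc(CNCCCNc2ccnc3cc(Cc4ccc(C#N)cc4)ccc23)c1O`, differs from compound 2 by 4-cyanobenzyl in place of 4-chlorophenoxy on an aromatic carbon.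

Within the data shown here, the one measured step that speaks to this kind of change is no change at the digits printed from compound 1 to compound 3 (within the scatter), where the group on the oxygen on the aromatic ring was exchanged with no change in this assay. The move from compound 2 to compound 4 is larger, in that the oxygen linking the ring leaves and a 4-cyanobenzyl enters, but it sits on the same part of the core, far from the chain that carries the amines. On this evidence compound 4 is expected to show a step of a number 0.02 log units higher from compound 2 to compound 4 (within the scatter), that is, none beyond the scatter. The estimate for compound 4 in this assay is therefore 9.3, within a range from 9 to 9.6.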

Compound 4, acid dissociation constant: 9.47
Compound 4: the middle estimate sits 0.17 log units below what was measured, within the range that was stated.
By their numbers in this assay, from the lowest: compounds 1, 2, 3 and 4 (each within the scatter of the next).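

In this assay, the exchange of 4-chlorophenoxy for 4-cyanobenzyl on an aromatic carbon gives a number 0.19 log units higher from compound 2 to compound 4 (within the scatter), so this change stays within the scatter. Among these compounds, the earlier step, no change at the digits printed from compound 1 to compound 3 (within the scatter), showed only that one aryl group on the oxygen could take the place of another; the new pair shows the same outcome when the whole 4-chlorophenoxy group leaves and a 4-cyanobenzyl group with its nitrile enters at this position, which is meta to a fused ring and para to a fused ring. Nothing measured here accounts for this outcome, and the result offers no explanation of its own.

The compounds shown leave open whether an amine or a carboxylic acid on this same aromatic carbon, in place of the aryl-bearing groups seen so far, would move the number beyond the scatter. They also leave open whether a longer chain carrying the two amines, rather than any change at this position, would do so, and no pair shown here speaks to that part of the molecule.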